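A difluoropyridine variant of compound 2

The compounds below may be only part of what the source reports. "The series", "measured", "known", "first", "only" and "open" are said of these compounds alone.

Measured compounds:
compound 1 `NS(=O)(=O)c1cccc(-c2nc(C(c3ccc(F)cc3)c3ccc(F)cc3)sc2CC(=O)O)c1`: 140 nM
compound 2 `O=C(O)Cc1sc(C(c2ccc(F)cc2)c2ccc(F)cc2)nc1-c1ccncc1`: 5.3 nM

Among the measured compounds shown here, in an in vitro assay on HEK385-7 cells for displacement of a labelled ligand from prostaglandin D2 receptor 2 (Homo sapiens) (a higher number here means a weaker inhibitor, a lower number a stronger inhibitor), compound 2 gives 5.3 nM and stands lowest of the two numbers; the only measured step, a 26-fold lower number from compound 1 to compound 2 (1.42 log units; beyond the scatter), is large and separates it from compound 1. Compound 3 `O=C(O)Cc1sc(C(c2ccc(F)cc2)c2ccc(F)cc2)nc1-c1cc(F)nc(F)c1` differs from compound 2 in one place: 2,6-difluoropyridin-4-yl in place of pyridin-4-yl on an aromatic carbon. For the measured compounds named here, that measured step exchanged one aromatic group for another of a different kind, whereas here the pyridin-4-yl remains and is only fluorinated, so no step directly bears on this change. The estimated step of a 1.5-fold higher number from compound 2 to compound 3 (0.18 log units; within the scatter) is therefore expected to be small, within the scatter. For compound 3 an estimate of 8 nM is expected, ranging from 2.5 nM to 25 nM.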

Compound 3, half-maximal inhibitory concentration: 5.4 nM
Beside the measured number, compound 3's estimate is 1.5-fold (0.17 log units) above it, within the range that was stated.
By their numbers in this assay, from the lowest: compounds 2 and 3 (each within the scatter of the next); then compound 1.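

In this assay, 2,6-difluoropyridin-4-yl in place of pyridin-4-yl gives a step within the scatter (a 1.0-fold higher number from compound 2 to compound 3 (0.01 log units; within the scatter)), so this aromatic carbon, next to the ring nitrogen, accepts the two added fluorine atoms at no measurable cost. The large step away from 3-sulfamoylphenyl also holds with the fluorinated group (a 26-fold lower number from compound 1 to compound 3 (1.41 log units; beyond the scatter)), so it is not confined to pyridin-4-yl itself. No measurement shown here accounts for either step. Going by these compounds, what an unsubstituted phenyl or a 2-aminopyridin-4-yl would give at this position remains open.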